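The source may report more compounds than this note shows. Statements on the series, on what has been measured and on what is new or still open speak of the compounds shown alone.

Compound 1 `Cc1ccc(S(=O)(=O)CC(C)C)cc1C#Cc1cc(Cl)ccc1OCC(=O)O`: 3 nM
Compound 2 `Cc1ccc(S(=O)(=O)N2CCCCC2C)cc1C#Cc1cc(Cl)ccc1OCC(=O)O`: 1.9 nM

Going by the values given here, in an assay on CHO cells for displacement of a labelled ligand from prostaglandin D2 receptor 2 (Homo sapiens), read by scintillation counting (on this read-out lower numbers stand for stronger inhibition and higher numbers for weaker inhibition), compound 2 stands lowest of these two numbers, but its only neighbour, compound 1, sits within the usual scatter, so the two cannot be ranked. Compound 3 `Cc1ccc(S(=O)(=O)NC(C)(C)C)cc1C#Cc1cc(Cl)ccc1OCC(=O)O` differs from compound 2 in one place: (tert-butyl)amino in place of 2-methylpiperidin-1-yl on a sulfonyl sulfur. Among the compounds with values here, the one measured step at this sulfonyl sulfur, a 1.6-fold lower number from compound 1 to compound 2 (0.20 log units; within the scatter), did not move the number beyond the scatter, which gives no ground to expect a shift now either. Compound 3 is therefore expected to give about 3 nM, somewhere from 1 nM to 10 nM. The expected step is a 1.6-fold higher number from compound 2 to compound 3 (0.20 log units; within the scatter).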

Compound 3, inhibition constant: 5 nM
Compound 3: middle estimate off by 1.7-fold (0.22 log units), on the low side, within the range that was stated.
By their numbers in this assay, from the lowest: compounds 2, 1 and 3 (each within the scatter of the next, the first and the last beyond it).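

In this assay, this sulfonyl sulfur gives its first step beyond the scatter, a modest one: a 2.6-fold higher number from compound 2 to compound 3 (0.42 log units; beyond the scatter). Compound 3 still cannot be separated from the isobutyl compound: a 1.7-fold higher number from compound 1 to compound 3 (0.22 log units; within the scatter). So a group with a hydrogen-bond donor and no ring can sit here with little change, though no measurement explains the step from the 2-methylpiperidin-1-yl group.

Open, on these data alone, is whether the ring or its methyl group matters, which plain piperidin-1-yl could test. (Tert-butyl)(methyl)amino could likewise test the amino hydrogen.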